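The compounds below may be only part of what the source reports. "The series", "measured", "known", "first", "only" and "open" are said of these compounds alone.

Among the measured compounds shown here, in an ADME assay on the whole organism for inhibition, with Echinochloa crus-galli var. formosensis as the target, with a stated time of 4 days (on this read-out higher numbers stand for weaker inhibition and lower numbers for stronger inhibition), compound 1 `CNc1nc(Cl)nc(N[C@@H](C)c2ccccc2)n1` gives 26900 nM, the higher of the two numbers so far, while compound 2 `CNc1nc(Cl)nc(N[C@H](C)c2ccccc2)n1` gives 562 nM. For the measured compounds named here, the single measured step, a 48-fold lower number from compound 1 to compound 2 (1.68 log units; beyond the scatter), is large, but it reflects configuration alone (the fact that compounds 1 and 2 differ only in the configuration as drawn) and does not touch the amine substituent. Compound 3 `CC(C)Nc1nc(Cl)nc(N[C@@H](C)c2ccccc2)n1` keeps the configuration drawn in compound 1 and changes methylamino to isopropylamino: isopropyl in place of methyl on a nitrogen on an aromatic ring. Going by the values given here, no measured step covers this change, so the expected step in this assay, a 1.3-fold lower number from compound 1 to compound 3 (0.13 log units; within the scatter), is no shift beyond the scatter. The estimated value for compound 3 is 20000 nM, within an expected range of 4000 nM to 80000 nM.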

Compound 3, half-maximal inhibitory concentration: 11000 nM
The estimate for compound 3 lay 1.8-fold (0.26 log units) above the measured number; measured number inside the range.
By their numbers in this assay, from the lowest: compound 2; then compound 3; then compound 1.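

In this assay the group on this nitrogen proves able to move the number: isopropyl in place of methyl gives a 2.4-fold lower number from compound 1 to compound 3 (0.39 log units; beyond the scatter) and so a modest gain in inhibition, whereas the earlier step changed only configuration. Among the compounds shown here, this is the first sign that the position responds to a change in the group itself, with the configuration of compound 1 held fixed. Nothing available explains this shift.

As far as these compounds go, whether isopropyl has a similar effect with the configuration drawn in compound 2 remains open. So does the outcome with an ethyl group or a longer chain on this nitrogen.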